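Acid to amide in a thiazole carboxylic acid series

The source may hold more compounds than are shown below. What is called first, only, known or untested is meant among the compounds shown, and "the series" means these compounds.

Three closely related compounds share one core, differing only in the benzamide ring attached at one end. Compound 1 `CN1CCN(c2ccc(Nc3nc(-c4cccc(NC(=O)c5ccccc5)c4)sc3C(=O)O)cc2)CC1` carries an unsubstituted phenyl on that carbonyl, and in a functional assay on Ramos cells (Homo sapiens) for antiproliferative activity, read by CCK-8 assay, with a stated time of 72 h (a higher number here means a weaker inhibitor, a lower number a stronger inhibitor), compound 1 gives "not determined" (no result reported). Compound 2 `CN1CCN(c2ccc(Nc3nc(-c4cccc(NC(=O)c5cccc(F)c5)c4)sc3C(=O)O)cc2)CC1` carries a fluorine on that ring and in this assay compound 2 gives 14000 nM. Compound 3 `CN1CCN(c2ccc(Nc3nc(-c4cccc(NC(=O)c5ccc(Cl)cc5)c4)sc3C(=O)O)cc2)CC1` carries a chlorine instead, and in this assay compound 3 gives 23300 nM. The step of a 1.7-fold higher number from compound 2 to compound 3 (0.22 log units; within the scatter) is the only measured one, and it concerns the benzamide ring, not the part changed next. Compound 3 thus stands with the higher of two numbers, but within the scatter of compound 2.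

Compound 4 `CN1CCN(c2ccc(Nc3nc(-c4cccc(NC(=O)c5ccc(Cl)cc5)c4)sc3C(N)=O)cc2)CC1` differs from compound 3 by amino in place of hydroxy on a carbonyl carbon. Among the compounds with values here, no measured step touches this part of the molecule, so nothing among the measured compounds predicts its effect. An expected step of a 1.9-fold lower number from compound 3 to compound 4 (0.29 log units; within the scatter) is therefore only a guess, with wide uncertainty. For compound 4 the estimate in this assay is 12000 nM, expected to fall between 2000 nM and 60000 nM.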

Compound 4, half-maximal inhibitory concentration: 1360 nM
The estimate for compound 4 lay 8.8-fold (0.95 log units) above the measured number, outside the stated range (below it).
By their numbers in this assay, from the lowest: compound 4; then compounds 2 and 3 (each within the scatter of the next).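

In this assay, amino in place of hydroxy on the carbonyl carbon gives a 17-fold lower number from compound 3 to compound 4 (1.23 log units; beyond the scatter), the first step among these compounds that lies beyond the scatter. The only earlier step, on the benzamide ring, was a 1.7-fold higher number from compound 2 to compound 3 (0.22 log units; within the scatter), so among the compounds shown, carboxy to carbamoyl is the one change that clearly moves the number, although the swap replaces a single oxygen with a single nitrogen. Nothing available accounts for the size of this step.

Going by these compounds, the step has been read only with the 4-chlorophenyl ring in place, so whether carbamoyl brings a similar gain alongside the 3-fluorophenyl ring of compound 2 stays open. Also open, on these data alone, is how a methyl ester, a nitrile or an N-methyl amide would compare with carbamoyl at this carbonyl position.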